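Notes on compound 2 and its mirror image, compound 4

This account rests on a few compounds, and the source may have more. Where it says the series, first, only, none or still open, it means among the compounds named here.

Measured compounds:
compound 1 `CCOC(=O)C1(C(=O)Nc2ccccc2)CC1c1cc(OC)c(OC)c(OC)c1`: 49000 nM; > 100000 nM (2 entries)
compound 2 `COc1cc([C@H]2C[C@]2(CO)C(=O)Nc2ccccc2Cl)cc(OC)c1OC`: 40200 nM
compound 3 `CCOC(=O)C1(C(=O)NCc2ccccc2)CC1c1cc(OC)c(OC)c(OC)c1`: 89600 nM; > 100000 nM (2 entries)

Among the measured compounds shown here, in a functional assay on SW480 cells (Homo sapiens) for cytotoxicity, read by MTT assay, with a stated time of 48 h (on this read-out higher numbers stand for weaker inhibition and lower numbers for stronger inhibition), compound 2 is the only compound of the three that returns a single number, 40200 nM. The entries of compound 1 in this assay include values that are limits of the assay and not numbers, as the several entries of compound 1 in this assay, 49000 nM; > 100000 nM (2 entries) shows. The entries of compound 3 in this assay likewise include limits of the assay, as the several entries of compound 3 in this assay, 89600 nM; > 100000 nM (2 entries) shows. For the measured compounds named here, compound 2 therefore stands as the sole anchor for any reading of this small set.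

Compound 4 `COc1cc([C@@H]2C[C@@]2(CO)C(=O)Nc2ccccc2Cl)cc(OC)c1OC` is the unmeasured partner of compound 2. The change is the two compounds have the same atoms and bonds and differ only in configuration as drawn: 2 of 2 stereo elements differ (all stereocentres are inverted: mirror images); a stereocentre at a saturated ring carbon is drawn R in compound 2 and S in compound 4; a stereocentre at a saturated ring carbon is drawn S in compound 2 and R in compound 4.

Going by the values given here, no pair of measured compounds differs only in configuration, so there is no measured step of this kind to lean on. A mirror-image pair can sit anywhere from no change beyond the scatter to a clear loss in this assay; with nothing measured in this direction, the expectation is placed modestly weaker than compound 2, with a wide range.

Compound 4 is expected at 65000 nM, between 20000 nM and 200000 nM, which corresponds to an expected step of a 1.6-fold higher number from compound 2 to compound 4 (0.21 log units; within the scatter) in this assay.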

Compound 4, half-maximal inhibitory concentration: 10700 nM
For compound 4 the middle estimate is 6.1-fold (0.78 log units) above the measured one; measured number outside the range, below it.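

In this assay, the configuration at the two saturated ring carbons makes a difference on its own, with a 3.8-fold lower number from compound 2 to compound 4 (0.57 log units; beyond the scatter), and compound 4 is the stronger member of this pair. The step can be assigned to configuration alone, because nothing else separates the two structures: the fact that compounds 2 and 4 differ only in the configuration as drawn

Among the compounds shown here, neither compound 1 nor compound 3 is drawn with a configuration at these ring carbons, so the earlier compounds gave no reading of this kind, and the order of the mirror images is new information about this part of the series.

Compound 2 and compound 4 are the only mirror-image pair shown, so it remains open whether the same order would hold on the shared core with the hydroxymethyl group replaced by a carboxylic acid, an amine or a longer chain. Going by these compounds, it also remains open whether the ethyl esters compound 1 and compound 3 would separate in the same direction as single mirror images, or whether the order would persist in a cell line other than the one used in this assay.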